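Hydroxyl placement on the carbonyl-side ring: compound 2 to 3

The source may hold more compounds than are shown below. What is called first, only, known or untested is meant among the compounds shown, and "the series" means these compounds.

Working notes. Compound 1 `O=C(/C=C/c1ccccc1OC(F)(F)F)c1ccccc1` carries an unsubstituted ring on the carbonyl carbon. In a functional assay on RAW264.7 cells (Mus musculus) for inhibition, read by fluorescence, with stated times of 1 h, 24 h and 30 min (on this read-out lower numbers stand for stronger inhibition and higher numbers for weaker inhibition), compound 1 gives > 10000 nM, which is a limit of the assay and not a number. Compound 2 `O=C(/C=C/c1ccccc1OC(F)(F)F)c1ccccc1O` carries a hydroxyl on that ring. In this assay compound 2 gives "not determined" (no result reported), so compound 2 has no number of its own on which to stand. The only other evidence shown is the limit of > 10000 nM in this assay, at which 1 of the 2 values shown sits, and compound 1 is the one sitting there. Compound 3 `O=C(/C=C/c1ccccc1OC(F)(F)F)c1ccc(O)cc1` is the isomer of compound 2: 4-hydroxyphenyl in place of 2-hydroxyphenyl on a carbonyl carbon. No step between measured compounds is shown, so the size of the step in this assay cannot be read from the series; with compound 1 at a limit and compound 2 without a number, neither a direction nor a size beyond the scatter can be supported, and a step within the scatter is as plausible as any other. For compound 3 the value expected in this assay is 8000 nM, estimated to fall between 2000 nM and 30000 nM, with a real chance that only a limit is reported.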

Compound 3, half-maximal inhibitory concentration: 1340 nM
Estimate against measurement, compound 3: 6.0-fold (0.78 log units) above, outside the stated range (below it).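

In this assay, among these compounds, the change from the unsubstituted ring on the carbonyl carbon to 4-hydroxyphenyl comes with an at least 7.4-fold lower number from compound 1 to compound 3 (0.87 log units; beyond the scatter), the first step that can be read and one that lies beyond the scatter. The ring on the carbonyl carbon is thus a place where a hydroxyl can change the read-out, something compound 1 alone could not show; compound 2 has no reported result, so the steps involving compound 2, including the one between the two hydroxyl isomers, cannot be read. The step printed is a minimum and not a size, as compound 1 sits at a limit of the assay and not at a number: the limit of > 10000 nM in this assay, at which 1 of the 3 values shown sits.

Whether the hydroxyl itself is needed on this ring stays open, as a methoxy group, an amine or a carboxylic acid in its place is not among the compounds shown. Also open is how much the trifluoromethoxy group on the other ring contributes, since every compound shown carries it and none has a chlorine or a plain hydrogen there.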